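The source may hold more compounds than are shown below. What is called first, only, known or untested is meant among the compounds shown, and "the series" means these compounds.

Values in a functional assay on MDA-MB-231 cells (Homo sapiens) for cytotoxicity, read by MTT assay, with a stated time of 72 h (a higher number here means a weaker inhibitor, a lower number a stronger inhibitor), for the measured compounds:
compound 1 `COc1cc2c(Oc3ccc(NC(=O)c4nn(-c5cccc(F)c5)c(=O)c5ccccc45)cc3F)ccnc2cc1OCCCN1CCCC1`: 880 nM
compound 2 `COc1cc2c(Oc3ccc(NC(=O)c4nn(-c5ccc(Br)cc5)c(=O)c5ccccc45)cc3F)ccnc2cc1OCCCN1CCCC1`: 1160 nM
compound 3 `COc1cc2c(Oc3ccc(NC(=O)c4nn(-c5ccccc5Br)c(=O)c5ccccc45)cc3F)ccnc2cc1OCCCN1CCCC1`: 1020 nM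

In this assay compound 3 gives 1020 nM, the second highest of the three numbers; the steps of a 1.1-fold lower number from compound 2 to compound 3 (0.06 log units; within the scatter) and a 1.2-fold higher number from compound 1 to compound 3 (0.06 log units; within the scatter) are both within the scatter, so the three compounds cannot be told apart on these numbers.

Compound 4 `COc1ccc(-n2nc(C(=O)Nc3ccc(Oc4ccnc5cc(OCCCN6CCCC6)c(OC)cc45)c(F)c3)c3ccccc3c2=O)cc1` differs from compound 3 in one place: 4-methoxyphenyl in place of 2-bromophenyl on an aromatic nitrogen. Every measured step bears on this change, since each of them likewise exchanges the aryl group on the same aromatic nitrogen: a 1.3-fold higher number from compound 1 to compound 2 (0.12 log units; within the scatter), a 1.2-fold higher number from compound 1 to compound 3 (0.06 log units; within the scatter), a 1.1-fold lower number from compound 2 to compound 3 (0.06 log units; within the scatter), all within the scatter. Going by these compounds, none of them brings in a 4-methoxyphenyl or a hydrogen-bond acceptor at that place, so that part of the change is untested. On the shown steps the expectation for compound 4 is no step beyond the scatter in this assay, a 1.0-fold lower number from compound 3 to compound 4 (0.01 log units; within the scatter). Compound 4 is therefore estimated at 1000 nM, with a range of 450 nM to 2300 nM.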

Compound 4, half-maximal inhibitory concentration: 3450 nM
Compound 4: middle estimate off by 3.5-fold (0.54 log units), on the low side; measured number outside the range, above it.
By their numbers in this assay, from the lowest: compounds 1, 3 and 2 (each within the scatter of the next); then compound 4.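

In this assay the aryl group on this aromatic nitrogen proves able to move the number, with a 3.4-fold higher number from compound 3 to compound 4 (0.53 log units; beyond the scatter) and a 3.9-fold higher number from compound 1 to compound 4 (0.59 log units; beyond the scatter) both beyond the scatter, whereas exchanges among the 3-fluorophenyl, 4-bromophenyl and 2-bromophenyl groups stayed within it. The closest comparison is methoxy in place of bromo on an aromatic carbon, a 3.0-fold higher number from compound 2 to compound 4 (0.47 log units; beyond the scatter), so the substituent itself matters and not only where it sits on the phenyl ring. Nothing measured here accounts for this step.

Compound 4 is the only compound shown with a hydrogen-bond acceptor on this aryl group, so a single example carries the whole effect. Going by these compounds, whether the number rises further or falls back with ethoxy, a dimethylamino group or a carboxylic acid on the same phenyl ring remains open.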